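The source may report more compounds than this note shows. Statements on the series, on what has been measured and on what is new or still open speak of the compounds shown alone.

Within the data shown here, compound 1 `CCOC(=O)NC(=O)NC1=CS(=O)(=O)O[C@@]12[C@@H](CO[Si](C)(C)C(C)(C)C)O[C@@H](n1cc(C)c(=O)n(C)c1=O)[C@@H]2O[Si](C)(C)C(C)(C)C` gives 14000 nM in a functional assay on HEL cells (Homo sapiens) (a lower number here means that less compound is tolerated, a higher number that more compound is tolerated), the lower of the two numbers measured so far. Compound 2 `COC(=O)CC(=O)NC1=CS(=O)(=O)O[C@@]12[C@@H](CO[Si](C)(C)C(C)(C)C)O[C@@H](n1cc(C)c(=O)n(C)c1=O)[C@@H]2O[Si](C)(C)C(C)(C)C` gives 29000 nM in this assay , which is a 2.1-fold higher number from compound 1 to compound 2 (0.32 log units; beyond the scatter). Compound 3 `Cc1cn([C@@H]2O[C@H](CO[Si](C)(C)C(C)(C)C)[C@@]3(OS(=O)(=O)C=C3NC(=O)c3ccccc3)[C@H]2O[Si](C)(C)C(C)(C)C)c(=O)n(C)c1=O` differs from compound 1 by phenyl in place of (ethoxycarbonyl)amino on a carbonyl carbon. Among the measured compounds shown here, the single measured step also swapped the group on that same carbonyl carbon and shifted this assay only modestly, so the change to compound 3 is expected to move the number little, if anything slightly upward. Compound 3 is therefore estimated at 18000 nM, within 7000 nM to 45000 nM, an expected step of a 1.3-fold higher number from compound 1 to compound 3 (0.11 log units; within the scatter).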

Compound 3, half-maximal cytotoxic concentration: 9700 nM
Beside the measured number, compound 3's estimate is 1.9-fold (0.27 log units) above it; measured number inside the range.
By their numbers in this assay, from the lowest: compounds 3 and 1 (each within the scatter of the next); then compound 2.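

In this assay swapping (ethoxycarbonyl)amino for phenyl, a group with no hydrogen-bond donors or acceptors, gives a 1.4-fold lower number from compound 1 to compound 3 (0.16 log units; within the scatter) and so does not separate the two groups on this carbonyl carbon. Phenyl in place of (methoxycarbonyl)methyl gives a 3.0-fold lower number from compound 2 to compound 3 (0.48 log units; beyond the scatter) and leaves compound 2 as the most tolerated of the three. Nothing measured here explains these shifts.

As far as these compounds go, how an amine, a carboxylic acid or a longer alkyl chain on that carbonyl carbon would read in this assay remains open. So does whether a substituted phenyl would stay level with phenyl.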